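A few compounds are considered here, and "the series" means these few. Any claim that something is new, unique, unknown or untested is made for them only; others in the source may bear on it.

Of the compounds shown here, two have been measured so far. Compound 1 `C[C@@H]1CN(c2cccc(NS(=O)(=O)c3ccc(-c4ccccn4)s3)c2)C[C@H](C)N1` gives 39.8 nM in a functional assay for agonist activity at growth hormone secretagogue receptor type 1 (Homo sapiens), read by FLIPR; a lower number here means that less compound is needed, a higher number that more compound is needed for the effect. Compound 2 `COc1ccc(N2C[C@@H](C)N[C@@H](C)C2)cc1NS(=O)(=O)c1ccc(-c2ccncc2)cc1` gives 316 nM in this assay, which is the higher of the two numbers, and the gap between compound 1 and compound 2 lies beyond the usual scatter of the measurement. Compound 3 `COc1ccc(N2C[C@@H](C)N[C@@H](C)C2)cc1NS(=O)(=O)c1ccc(-c2cccs2)cc1` is derived from compound 2 by a single exchange: thiophen-2-yl in place of pyridin-4-yl on an aromatic carbon. For the measured compounds named here, no pair of measured compounds shows this exchange, so its effect in this assay cannot be read from the data; compound 1 carries a different pyridyl group on a different ring and gives no guide here. For compound 3 the step of a 1.3-fold lower number from compound 2 to compound 3 (0.10 log units; within the scatter) is expected to be small and to stay within the scatter, with the direction open. Compound 3 is therefore estimated at 250 nM in this assay, within a range from 60 nM to 1000 nM.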

Compound 3, half-maximal effective concentration: 3.98 nM
Estimate against measurement, compound 3: 63-fold (1.80 log units) above; the whole stated range lies above it.
By their numbers in this assay, from the lowest: compound 3; then compound 1; then compound 2.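

The exchange of pyridin-4-yl for thiophen-2-yl, on an aromatic carbon para to a large group, brings a 79-fold lower number from compound 2 to compound 3 (1.90 log units; beyond the scatter) in this assay. For the compounds shown here, this is the first pair here that differs in one place, and it shows that the group at this position strongly affects how much compound is needed, so these two aromatic rings are not interchangeable. Both groups count 0 hydrogen-bond donors and 1 hydrogen-bond acceptor, so those counts do not separate them, and no measurement at hand explains the step.

Going by these compounds, whether the lower number follows the five-membered ring or the sulfur stays open, and a furan-2-yl or plain phenyl group at this position would help separate the two. Also open, on these data alone, is whether thiophen-2-yl would have a similar effect on the core of compound 1.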